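The source may report more compounds than this note shows. Statements on the series, on what has been measured and on what is new or still open speak of the compounds shown alone.

Compound 1 `CCOc1nc(N)nc2c1ncn2/C=C1/CC1(CO)CO` — > 300000 nM
Compound 2 `CCCCCCCCOc1nc(N)nc2c1ncn2/C=C1/CC1(CO)CO` — > 300000 nM
Compound 3 `Nc1nc(N2CCCC2)c2ncn(/C=C3/CC3(CO)CO)c2n1` — > 300000 nM

In an ADME assay on HFF cells (Homo sapiens) for cytotoxicity, with a stated time of 8 days (a higher number here means that more compound is tolerated, a lower number that less compound is tolerated), compound 1 reaches only the limit > 300000 nM. Compound 2 likewise stops at a limit, > 300000 nM. Compound 3 too sits at a limit, > 300000 nM, so its standing among these three cannot be placed: all of them share (the limit of > 300000 nM in this assay, at which 3 of the 3 values shown sit). The steps a step that the two limits leave unreadable from compound 1 to compound 2, a step that the two limits leave unreadable from compound 1 to compound 3 and a step that the two limits leave unreadable from compound 2 to compound 3 therefore have no readable size. Compound 4 `CC(C)Sc1nc(N)nc2c1ncn2/C=C1/CC1(CO)CO` differs from compound 3 by isopropylsulfanyl in place of pyrrolidin-1-yl on an aromatic carbon. Among the compounds with values here, no measured step bears readably on this change, and compound 3 itself stands at the limit. Compound 4 is expected to give 300000 nM, between 150000 nM and 600000 nM. The expected step of a number no higher from compound 3 to compound 4 (the limit leaves the size open) is thus estimated to stay within the scatter, most probably again as a limit.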

Compound 4, half-maximal cytotoxic concentration: > 300000 nM
Compound 4: no number, only a limit (the forecaster's own chance of this, stated with the estimate: 85%); the middle value lies on the limit itself.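

Compound 4 stops at a limit, as do compound 1, compound 2 and compound 3, so no step between compound 4 and any of them can be read: the limit of > 300000 nM in this assay, at which 4 of the 4 values shown sit.

The compounds shown leave open how far any one of them differs from another in this assay.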